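This account rests on a few compounds, and the source may have more. Where it says the series, first, only, none or still open, it means among the compounds named here.

Working notes on the series, all read in a functional assay on Raji cells (Homo sapiens) for cytotoxicity, with a stated time of 72 h; on this read-out lower numbers stand for an effect already at smaller amounts and higher numbers for an effect only at larger amounts of compound. Compound 1 (`C=C[C@@](C)(/C=C/c1ccc(O)cc1)CC/C=C(\C)C=O`) gives > 26000 nM, a limit of the assay and not a number. Compound 2 (`C=C[C@@](C)(/C=C/c1ccc(O)c(/C=C/c2ccc(F)cc2)c1)CCC=C(C)C`) gives > 26000 nM, which is also a limit. Compound 3 (`CCOc1ccc(/C=C/[C@@](C)(/C=C/c2ccc(O)cc2)CCC=C(C)C)cc1`) gives > 26000 nM, again a limit. Compound 3 therefore has no number of its own and cannot be ranked against the other two, since all of them sit at the limit of > 26000 nM in this assay, at which 3 of the 3 values shown sit.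

Compound 4 (`CC(C)=CCC[C@](C)(/C=C/c1ccc(O)cc1)/C=C/c1ccc(C#N)cc1`) differs from compound 3 by cyano in place of ethoxy on an aromatic carbon; the 4-ethoxyphenyl becomes 4-cyanophenyl. For the measured compounds named here, no measured step gives the size of this change. No step beyond the scatter is expected in this assay, and no direction is favoured. This expectation rests on compound 3 and its neighbours sharing (the limit of > 26000 nM in this assay, at which 3 of the 3 values shown sit). The estimated change is a number no higher from compound 3 to compound 4 (the limit leaves the size open). A second report as a limit is the likeliest outcome. For compound 4 the expected value is 26000 nM, with an estimated range of 12000 nM to 40000 nM.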

Compound 4, half-maximal effective concentration: > 26000 nM
Compound 4: only a limit was reported; the forecaster's own chance of this, stated with the estimate: 75%; the middle value sits exactly at the limit.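

In this assay compound 4 gives > 26000 nM, a limit of the assay and not a number. No step can be read between compound 3 and compound 4, since both stand only as limits: the limit of > 26000 nM in this assay, at which 4 of the 4 values shown sit. The compounds shown leave open whether cyano in place of ethoxy changes the read-out at all, and in which direction.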